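The source may report more compounds than this note shows. Statements on the series, on what has been measured and on what is new or still open speak of the compounds shown alone.

Compound 1 `CCOc1ccc2nc(C(=O)Nc3c(F)cc(-c4cccc(F)c4)cc3F)c(C)c(O)c2c1` belongs to a small set of three closely related compounds tested in a functional assay on A-375 cells (Homo sapiens) for antiproliferative activity, read by MTT assay, with a stated time of 24 h, tested at 1.23 ug/mL; a lower number here means a weaker effect, a higher number a stronger effect of the compound at the concentration tested. Compound 1 gives 2.96%, which places it second highest of the three. Compound 2 `Cc1c(C(=O)Nc2c(F)cc(-c3cccc(F)c3)cc2F)nc2ccc(OC(F)(F)F)cc2c1O` gives 1.57%, and the step of a number 1.4 percentage points lower from compound 1 to compound 2 (within the scatter) lies within the scatter, so the two cannot be told apart. Compound 3 `Cc1c(C(=O)Nc2c(F)cc(-c3cccc(F)c3)cc2F)nc2ccc(C(F)(F)F)cc2c1O` gives 21.3%, and the step of a number 18.3 percentage points higher from compound 1 to compound 3 (beyond the scatter) is beyond the scatter; likewise a number 19.7 percentage points higher from compound 2 to compound 3 (beyond the scatter). All three of these measured steps alter the group on the aromatic carbon of the outer ring, not the hydroxy group.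

Compound 4 `CCOc1ccc2nc(C(=O)Nc3c(F)cc(-c4cccc(F)c4)cc3F)c(C)c(C(=O)O)c2c1` differs from compound 1 in a different place: carboxy in place of hydroxy on an aromatic carbon. Among the measured compounds shown here, none of the measured steps touches this position, so there is no directly comparable step to lean on. With no evidence either way, the expectation for compound 4 is a step of no more than the usual scatter, a number 2 percentage points higher from compound 1 to compound 4 (within the scatter), staying close to the value of compound 1. The estimate for compound 4 in this assay is therefore 5%, expected to fall somewhere between 0% and 20%.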

Compound 4, a percentage reported as inhibition, at one concentration (the size of the read-out at that concentration, not a potency): 26.7%
The estimate for compound 4 lay 21.7 percentage points below the measured number, outside the stated range (above it).
By their numbers in this assay, from the lowest: compounds 2 and 1 (each within the scatter of the next); then compounds 3 and 4 (each within the scatter of the next).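

Carboxy in place of hydroxy gives, in this assay, a number 23.7 percentage points higher from compound 1 to compound 4 (beyond the scatter), so the position opposite the ring nitrogen can also change the read-out, whereas all the earlier steps concerned only the group on the outer ring. The change swaps a single oxygen for a group of 3 heavy atoms with a double bond outside aromatic rings, while the counts of hydrogen-bond donors and acceptors stay the same, so a difference in those counts cannot be what separates the two compounds. No measurement here bears on why this replacement raises the number, and the reason stays unknown.

As far as these compounds go, this position is described by a single replacement on a single background, so it remains open how an amine or a methyl ester would behave there, and whether a longer chain ending in a carboxylic acid would keep the step. From the compounds shown here alone, it is also open whether carboxy would give a step of similar size alongside trifluoromethyl or trifluoromethoxy instead of ethoxy, and whether the result would hold at other concentrations.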